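The source may hold more compounds than are shown below. What is called first, only, known or untested is meant among the compounds shown, and "the series" means these compounds.

Compound 1, `CN(C(=O)NC(=O)c1ccc(Cl)cc1Cl)c1nc(C(F)(F)F)c(C(=O)N/N=C/c2ccc(C(F)(F)F)cc2)s1`, in a functional assay on A549 cells (Homo sapiens) for inhibition, read by MTT assay, with a stated time of 72 h (a higher number here means a weaker inhibitor, a lower number a stronger inhibitor), gives 9.4 ug/mL.
Compound 2, `CN(C(=O)NC(=O)c1cccc(C(F)(F)F)c1)c1nc(C(F)(F)F)c(C(=O)N/N=C/c2ccc(C(F)(F)F)cc2)s1`, in this assay gives 6.2 ug/mL.
Compound 3, `CN(C(=O)NC(=O)c1ccc(Cl)cc1Cl)c1nc(C(F)(F)F)c(C(=O)N/N=C/c2cc(C(F)(F)F)cc(C(F)(F)F)c2)s1`, in this assay gives only a limit of the assay, > 100 ug/mL.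

Compound 4, `CN(C(=O)NC(=O)c1cccc(C(F)(F)F)c1)c1nc(C(F)(F)F)c(C(=O)N/N=C/c2cc(C(F)(F)F)cc(C(F)(F)F)c2)s1`, has not yet been measured in this assay. It stands to compound 3 as compound 2 stands to compound 1: the change is 3-(trifluoromethyl)phenyl in place of 2,4-dichlorophenyl on a carbonyl carbon, and the same change, (3-(trifluoromethyl)phenyl in place of 2,4-dichlorophenyl on a carbonyl carbon), has already been measured as a 1.5-fold lower number from compound 1 to compound 2 (0.18 log units; within the scatter). The difference between the core of compound 1 and the core of compound 3 is not broken down here. The measured step is within the scatter, so the step from compound 3 to compound 4 is expected to be of similar small size, a number no higher from compound 3 to compound 4 (the limit leaves the size open). Compound 3 sits at the limit of > 100 ug/mL in this assay, at which 1 of the 3 values shown sits. A small step from a limit leaves compound 4 expected at or near that same limit, so the assay may again report only a limit for it. The estimate for compound 4 in this assay is 100 ug/mL, with a range from 50 ug/mL to 200 ug/mL.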

Compound 4, half-maximal inhibitory concentration: 8.2 ug/mL
Compound 4: middle estimate off by 12-fold (1.09 log units), on the high side; measured number below the stated range.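

In this assay the change from 2,4-dichlorophenyl to 3-(trifluoromethyl)phenyl on the carbonyl carbon gives an at least 12-fold lower number from compound 3 to compound 4 (1.08 log units; beyond the scatter), so it did not carry over at the small size it had on the core of compound 1, and the two steps differ: the same change on two cores in this assay, a 1.5-fold lower number (0.18 log units; within the scatter) from compound 1 to compound 2 and an at least 12-fold lower number (1.08 log units; beyond the scatter) from compound 3 to compound 4, at least 8.0-fold (0.90 log units) apart, beyond the scatter of two such steps. Compound 3 gives only a limit of the assay, which leaves the size of the new step open on one side: the limit of > 100 ug/mL in this assay, at which 1 of the 4 values shown sits. The result shows that in this series the effect of this change depends on the core it sits on, but it does not show what in the cores produces the difference, and two cores give no rule for a third.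

The compounds shown leave open whether a phenyl carrying a methoxy group or a nitrile in place of 3-(trifluoromethyl)phenyl would give a similar result on these two cores. They also leave open whether the same difference between the cores would appear on other cell lines.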